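The compounds below may be only part of what the source reports. "The series", "measured", "known", "first", "only" and "open" are said of these compounds alone.

In an ADME assay on Karpas-1106P cells (Homo sapiens) for cytotoxicity (on this read-out lower numbers stand for an effect already at smaller amounts and higher numbers for an effect only at larger amounts of compound), two compounds have been measured so far. Compound 1 `Cc1ccc(S(=O)(=O)N[C@@H](CC(=O)NC(C)(C)C)C(=O)NCCNC(=O)c2ccccc2)cc1` gives > 11100 nM, which is a limit of the assay and not a number. Compound 2 `Cc1ccc(S(=O)(=O)N[C@@H](CC(=O)NC(C)(C)C)C(=O)NCCNC(=O)Nc2ccccc2)cc1` gives > 11100 nM, which is likewise only a limit. The standing of compound 2 is therefore known only as the limit of > 11100 nM in this assay, at which 2 of the 2 values shown sit.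

Compound 3 `Cc1ccc(S(=O)(=O)N[C@@H](CC(=O)NC(C)(C)C)C(=O)NCCNC(=O)c2ccccc2F)cc1` differs from compound 2 at one place, with 2-fluorophenyl in place of anilino on a carbonyl carbon. For the measured compounds named here, the one measured step at this place is a step that the two limits leave unreadable from compound 1 to compound 2, in which anilino took the place of phenyl, and it offers no size to carry forward. With only this to go on, no step beyond the usual scatter is expected in this assay, no direction can be named, and the read-out will most likely again be a limit. The estimated step is a step that the limit leaves unreadable from compound 2 to compound 3. For compound 3 the expected value is 12000 nM, with an estimated range of 6000 nM to 30000 nM.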

Compound 3, half-maximal effective concentration: > 11100 nM
Compound 3 was reported as a limit; the forecaster's own chance of this, stated with the estimate: 80%; the middle value does not contradict the limit.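

In this assay no step can be read among compound 1, compound 2 and compound 3, since each comparison sets one limit against another, and all three share a single reading: the limit of > 11100 nM in this assay, at which 3 of the 3 values shown sit.

The compounds shown leave open whether phenyl, anilino and 2-fluorophenyl on a carbonyl carbon differ in cytotoxicity at all.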